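Chloro for Methyl on the Benzyl Group of Compound 3

This account rests on a few compounds, and the source may have more. Where it says the series, first, only, none or still open, it means among the compounds named here.

Compound 1 `CCCCc1cnc(Cc2ccc(-c3ccccc3C(=O)O)cc2)[nH]1`, compound 2 `CCCCc1cnc(C(CCC)Cc2ccc(-c3ccccc3C(=O)O)cc2)[nH]1` and compound 3 `Cc1ccccc1Cc1cnc(CCc2ccc(-c3ccccc3C(=O)O)cc2)[nH]1` share one core and differ in the substituents on the imidazole. In an in vitro functional assay on cells for agonist activity at Bombesin receptor subtype-3 (Mus musculus), read by luminescence and calcium flux (on this read-out higher numbers stand for an effect only at larger amounts of compound and lower numbers for an effect already at smaller amounts), compound 1 reaches only the limit of > 10000 nM, which is not a number. Compound 2 gives 165 nM in this assay. Compound 3 gives 9.3 nM, the lowest of the two numbers, and compound 2 stands beyond the scatter from it. Compound 4 `O=C(O)c1ccccc1-c1ccc(CCc2ncc(Cc3ccccc3Cl)[nH]2)cc1` differs from compound 3 in a single place: chloro in place of methyl on an aromatic carbon. Among the measured compounds shown here, no measured pair shows this change, so any expectation rests on compound 3 alone. The step of a 1.3-fold higher number from compound 3 to compound 4 (0.11 log units; within the scatter) is expected to fall within the usual scatter. Compound 4 is estimated at 12 nM, between 4 nM and 40 nM.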

Compound 4, half-maximal effective concentration: 22 nM
Compound 4: the middle estimate sits 1.8-fold (0.26 log units) below what was measured; the range from low to high includes it.
By their numbers in this assay, from the lowest: compound 3; then compound 4; then compound 2. At a limit, above all of these: compound 1.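

With chloro in place of methyl on an aromatic carbon ortho to a large group, this assay gives a 2.4-fold higher number from compound 3 to compound 4 (0.37 log units; beyond the scatter). This is the first change in a single place among these compounds, and it shows that this position responds to the exchange of one heavy atom for another, though only modestly. Nothing measured here bears on why the number moves. Going by these compounds, what fluoro, methoxy or an amine would give at this position remains open. So does whether the same exchange would give a similar step elsewhere on the shared core.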